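From vinyl to but-3-en-1-yl on the side chain

The compounds below may be only part of what the source reports. "The series", "measured", "known", "first", "only" and "open" are said of these compounds alone.

Of the compounds shown here, three sharing one core have been measured so far. In a functional assay on SK-MEL-28 cells (Homo sapiens) for inhibition, read by colorimetric assay and MTT assay, with a stated time of 72 h (on this read-out higher numbers stand for weaker inhibition and lower numbers for stronger inhibition), compound 3 (`C=CCCOc1ncc(-c2ccccc2OC)n1C`) gives 21000 nM and compound 2 (`C#CCCCCOc1ncc(-c2ccccc2OC)n1C`) gives 38000 nM at the low end of the series, with a 1.8-fold lower number from compound 2 to compound 3 (0.26 log units; within the scatter) lying within the scatter. Compound 1 (`CCCCOc1ncc(-c2ccccc2OC)n1C`) gives 82000 nM and stands clearly higher, as a 3.9-fold lower number from compound 1 to compound 3 (0.59 log units; beyond the scatter) shows.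

Compound 4 (`C=CCCCCOc1ncc(-c2ccccc2OC)n1C`) carries but-3-en-1-yl in place of vinyl on a saturated chain carbon, two bonds along the chain from an oxygen on an aromatic ring.

Within the data shown here, the nearest precedent is the pair in which but-3-yn-1-yl and vinyl occupy this same place: compound 2 and compound 3, whose step stays within the scatter. The other steps are modest, with a 2.2-fold lower number from compound 1 to compound 2 (0.33 log units; beyond the scatter) and the step to compound 3 above, and both start from compound 1. Among the measured compounds shown here, no measured pair isolates the but-3-en-1-yl group itself. In this assay no step beyond the scatter is therefore expected, with a slightly higher number the more likely side.

The expected step is a 1.6-fold higher number from compound 3 to compound 4 (0.20 log units; within the scatter) in this estimate. For compound 4 the estimated value is 33000 nM within an expected range of 14000 nM to 75000 nM.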

Compound 4, half-maximal inhibitory concentration: 13000 nM
Compound 4: middle estimate off by 2.5-fold (0.40 log units), on the high side; the measured number lies below the stated range.
By their numbers in this assay, from the lowest: compounds 4, 3 and 2 (each within the scatter of the next, the first and the last beyond it); then compound 1.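

Extending the chain from but-3-en-1-yl to hex-5-en-1-yl on the oxygen does not separate the two alkenes in this assay: the data give a 1.6-fold lower number from compound 3 to compound 4 (0.21 log units; within the scatter), so this position accepts the longer alkene chain with no change that can be read beyond the scatter. Among these compounds, what the earlier compounds could not show is a comparison of a terminal alkene with a terminal alkyne on chains of the same length, and here a 2.9-fold lower number from compound 2 to compound 4 (0.47 log units; beyond the scatter), a step that favours the alkene, though only modestly; against the saturated butyl compound, the series now also spans a 6.3-fold lower number from compound 1 to compound 4 (0.80 log units; beyond the scatter). No measurement accompanies these numbers that could tie any of these steps to a cause.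

Chain length and unsaturation remain entangled in the step from compound 1 to compound 4, and a saturated hexyl chain on the same oxygen would be the compound to separate them. Also open, as far as these compounds go, is whether the trend continues with a longer alkenyl chain, or whether a polar end group such as a terminal amine or carboxylic acid is tolerated at the chain end.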